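Chain Extension on the Imide Nitrogen: Compound 2 to Compound 3

The compounds below may be only part of what the source reports. "The series", "measured", "known", "first", "only" and "open" are said of these compounds alone.

Measured so far:
- compound 1, `CCCCCN1C(=O)CCC(CC)(c2ccncc2)C1=O`: 209000 nM
- compound 2, `CCCCCCCN1C(=O)CCC(CC)(c2ccncc2)C1=O`: 210000 nM

In an assay on isolated protein for inhibition of cholesterol side-chain cleavage enzyme, mitochondrial (Bos taurus) (on this read-out higher numbers stand for weaker inhibition and lower numbers for stronger inhibition), compound 1 gives 209000 nM and compound 2 gives 210000 nM. Compound 2 holds the highest of the two numbers, with compound 1 as its nearest neighbour; the step of a 1.0-fold higher number from compound 1 to compound 2 (0.00 log units; within the scatter) lies within the scatter, so the two are not separated on this read-out.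

Compound 3, `CCCCCCCCN1C(=O)CCC(CC)(c2ccncc2)C1=O`, is not yet measured. It differs from compound 2 by methyl in place of hydrogen on a saturated chain carbon, seven bonds along the chain from an amide-type nitrogen in a ring. Among the measured compounds shown here, this is the same kind of change as the one from compound 1 to compound 2, a saturated chain on the ring nitrogen made longer, cut one bond further out.

For the measured compounds named here, the only step that bears on it is a 1.0-fold higher number from compound 1 to compound 2 (0.00 log units; within the scatter), which showed no movement beyond the scatter. On that basis the step of no change at the digits printed from compound 2 to compound 3 (within the scatter) is expected to show no change beyond the scatter either. Compound 3 is therefore estimated at 210000 nM, with a range from 100000 nM to 450000 nM.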

Compound 3, half-maximal inhibitory concentration: 110000 nM
The estimate for compound 3 lay 1.9-fold (0.28 log units) above the measured number, within the range that was stated.
By their numbers in this assay, from the lowest: compounds 3, 1 and 2 (each within the scatter of the next).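

Notes on the chain on the ring nitrogen. In this assay, methyl in place of hydrogen, seven bonds along the chain from an amide-type nitrogen in a ring, gives a 1.9-fold lower number from compound 2 to compound 3 (0.28 log units; within the scatter) and propyl in place of hydrogen, five bonds along the chain from that nitrogen, gives a 1.9-fold lower number from compound 1 to compound 3 (0.28 log units; within the scatter) as the wider comparison. The earlier pair covered only one extension, whereas these steps show that the chain can be carried out to its length in compound 3 with all three compounds still unseparated on this read-out, so no dependence on chain length can be claimed from compounds 1, 2 and 3. No independent measurement bears on this result.

From the compounds shown here alone, whether a longer chain would move the number beyond the scatter remains open, as does the outcome of ending the chain in an amine or a carboxylic acid rather than in methyl. All three compounds share the same core and the same ethyl and ring substituents, so what changes elsewhere on that core would do to the inhibition is also unresolved by this set.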